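A few compounds are considered here, and "the series" means these few. Any claim that something is new, unique, unknown or untested is made for them only; others in the source may bear on it.

Compound 1 `COc1ccc(S(=O)(=O)NCCN2CCC(CCC(=O)c3cc(Cl)c(N)cc3OC)CC2)cc1Cl` gives 20% in an assay on HEK293 cells for displacement of a labelled ligand from 5-hydroxytryptamine receptor 6 (Homo sapiens), with a stated time of 60 min, tested at 0.01 uM, in the presence of a further agent that is not named here (on this read-out lower numbers stand for a weaker effect and higher numbers for a stronger effect at the one concentration tested), the lowest of the two numbers reported. Compound 2 `COc1cc(N)c(Cl)cc1C(=O)CCC1CCN(CCNS(=O)(=O)c2cc(Br)c(N)c(Br)c2)CC1` gives 52% in this assay, and compound 3 `COc1cc(N)c(Cl)cc1C(=O)CCC1CCN(CCNS(=O)(=O)c2ccc3c(c2)NC(=O)CO3)CC1` is reported in this assay as "not active" (no number reported) without a number. For the measured compounds named here, the one measured step, a number 32 percentage points higher from compound 1 to compound 2 (beyond the scatter), shows that the aryl group on the sulfonyl sulfur can move the read-out a long way. Compound 4 `COc1cc(N)c(Cl)cc1C(=O)CCC1CCN(CCNS(=O)(=O)c2ccc(OC)c(N3CCN(C)CC3)c2)CC1` differs from compound 1 by 4-methylpiperazin-1-yl in place of chloro on an aromatic carbon. Going by the values given here, no measured step covers this exchange; the step from compound 1 to compound 2 alters the same ring in another way, so it indicates only that large shifts are possible, not their direction. The expected step is a number 5 percentage points higher from compound 1 to compound 4 (within the scatter), small and of uncertain sign. Compound 4 is estimated at 25%, with a range from 5% to 55%.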

Compound 4, a percentage reported as inhibition, at one concentration (the size of the read-out at that concentration, not a potency): 4%
Compound 4: the middle estimate sits 21 percentage points above what was measured, and the stated range ends above it.
By their numbers in this assay, from the lowest: compound 4; then compound 1; then compound 2.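

On the ring carrying the sulfonyl sulfur, the place ortho to a methoxy group is not neutral in this assay: 4-methylpiperazin-1-yl in place of chloro gives a number 16 percentage points lower from compound 1 to compound 4 (beyond the scatter). This exchange lowers the read-out, whereas the earlier change of aryl group on the sulfonyl sulfur raised it, so changes on this ring can move the number either way. Nothing measured here explains the drop. Open, going by these compounds, is whether it follows from losing chloro or from the entering 4-methylpiperazin-1-yl group; a dimethylamino group or a fluorine atom at this place would help separate the two.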